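Distal aryl swap: hydroxyphenyl to chlorophenyl, working notes

A few compounds are considered here, and "the series" means these few. Any claim that something is new, unique, unknown or untested is made for them only; others in the source may bear on it.

Among the compounds with values here, three cytotoxicity numbers define the series so far. In a functional assay on J774 cells (Mus musculus) for cytotoxicity, read by resazurin assay (a lower number here means a stronger inhibitor, a higher number a weaker inhibitor), compound 1 `Cc1ccccc1-c1ccc(C(O)CCCCCO)cc1` gives 24000 nM, compound 2 `Cc1ccc(-c2ccc(C(O)CCCCCO)cc2)cc1` gives 22000 nM, and compound 3 `OCCCCCC(O)c1ccc(-c2ccc(O)cc2)cc1` gives 15000 nM. Compound 3 holds the lowest of the three numbers, yet the step of a 1.5-fold lower number from compound 2 to compound 3 (0.17 log units; within the scatter) and the step of a 1.6-fold lower number from compound 1 to compound 3 (0.20 log units; within the scatter) both sit inside the scatter, so nothing separates the three compounds.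

Compound 4 `OCCCCCC(O)c1ccc(-c2cccc(Cl)c2)cc1` carries the change (3-chlorophenyl in place of 4-hydroxyphenyl on an aromatic carbon). The closest precedents are a 1.5-fold lower number from compound 2 to compound 3 (0.17 log units; within the scatter), a hydroxy-for-methyl exchange, and a 1.1-fold lower number from compound 1 to compound 2 (0.04 log units; within the scatter), a shift of the methyl on the ring; both lay within the scatter. Within the data shown here, no measured step therefore points to a change beyond the scatter, and the expected step is a 1.2-fold higher number from compound 3 to compound 4 (0.08 log units; within the scatter). Compound 4 is estimated at 18000 nM in this assay, within 7000 nM to 45000 nM.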

Compound 4, half-maximal inhibitory concentration: > 100000 nM
Compound 4: a limit, no number; the forecaster's own chance of this, stated with the estimate: 5%; middle value at least 5.5-fold (0.74 log units) from the limit.
By their numbers in this assay, from the lowest: compounds 3, 2 and 1 (each within the scatter of the next). At a limit, above all of these: compound 4.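

In this assay the value of compound 4 is a limit of the assay and not a number: the limit of > 100000 nM in this assay, at which 1 of the 4 values shown sits. This place on the distal ring, silent across the earlier exchanges, does respond to substitution: 3-chlorophenyl gives an at least 6.6-fold higher number from compound 3 to compound 4 (0.82 log units; beyond the scatter), and likewise an at least 4.5-fold higher number from compound 2 to compound 4 (0.65 log units; beyond the scatter) and an at least 4.1-fold higher number from compound 1 to compound 4 (0.61 log units; beyond the scatter). Compounds 1 and 2 also carry no hydroxy on that ring, so the step does not simply follow the loss of the hydrogen-bond donor.

From the compounds shown here alone, the full size of these steps stays open, as does whether the chlorine or its place on the ring carries them. Going by these compounds, how an amine or a carboxylic acid at this place would read is also open.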